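From benzyl to 2-chlorobenzyl in compound 3

The source may report more compounds than this note shows. Statements on the series, on what has been measured and on what is new or still open speak of the compounds shown alone.

In a functional assay on BGC-823 cells (Homo sapiens) for antiproliferative activity, read by MTT assay, with a stated time of 48 h (a higher number here means a weaker inhibitor, a lower number a stronger inhibitor), three compounds with a shared core have been measured. Compound 1 (`O=[N+]([O-])c1ccccc1CSc1nnc(-c2ccc3c(c2)OCCO3)o1`) gives 23300 nM, compound 2 (`Brc1ccccc1CSc1nnc(-c2ccc3c(c2)OCCO3)o1`) gives 21200 nM and compound 3 (`c1ccc(CSc2nnc(-c3ccc4c(c3)OCCO4)o2)cc1`) gives 33600 nM. On these numbers, compound 3 cannot be separated from the other two, as the data show a 1.4-fold higher number from compound 1 to compound 3 (0.16 log units; within the scatter) and a 1.6-fold higher number from compound 2 to compound 3 (0.20 log units; within the scatter).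

Compound 4 (`Clc1ccccc1CSc1nnc(-c2ccc3c(c2)OCCO3)o1`) differs from compound 3 by one substituent: chloro in place of hydrogen on an aromatic carbon. This places chloro in place of hydrogen on an aromatic carbon, ortho to a large group, and turns benzyl into 2-chlorobenzyl.

The nearest evidence comes from compound 2, which carries bromo, and compound 1, which carries nitro, where compound 4 carries chloro. Removing either group left the reading within the scatter, in the two steps already given. Exchanging one group for the other also made no clear difference, with a 1.1-fold lower number from compound 1 to compound 2 (0.04 log units; within the scatter). On these data alone, no step beyond the scatter is therefore expected in this assay, and the direction remains open. The estimate amounts to a 1.4-fold lower number from compound 3 to compound 4 (0.15 log units; within the scatter), which is an expected step of no clear size. Compound 4 is expected at about 24000 nM, with an estimated range from 14000 nM to 38000 nM.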

Compound 4, half-maximal inhibitory concentration: 22500 nM
Compound 4: the middle estimate sits 1.1-fold (0.03 log units) above what was measured; low and high end bracket the measured number.
By their numbers in this assay, from the lowest: compounds 2, 4, 1 and 3 (each within the scatter of the next).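

In this assay, chloro on this aromatic carbon, ortho to a large group, gives a 1.5-fold lower number from compound 3 to compound 4 (0.17 log units; within the scatter) and so joins bromo and nitro as a third group that cannot be separated from the plain benzyl compound. It also cannot be told apart from the other two substituted compounds, with a 1.1-fold higher number from compound 2 to compound 4 (0.03 log units; within the scatter) and a 1.0-fold lower number from compound 1 to compound 4 (0.02 log units; within the scatter) as the steps, so all the exchanges among chloro, bromo and nitro at this place now lie within the scatter, and the four compounds form one flat group with no order among them. Nothing available beyond these readings speaks to why this place responds so little to the groups tried there.

On these data alone, whether an amine, a carboxylic acid, a methoxy group or a longer chain at the same place would move the reading beyond the scatter remains open. Also open, as far as these compounds go, is whether chloro on another carbon of this ring, or any change elsewhere on the shared core, would separate a compound from these four in this assay.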